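The compounds below may be only part of what the source reports. "The series", "measured", "known", "first", "only" and "open" are said of these compounds alone.

Measured so far in an ADME assay on cells for inhibition of cytochrome P450 11B1, mitochondrial (Homo sapiens), read by HTRF; on this read-out lower numbers stand for stronger inhibition and higher numbers for weaker inhibition:

Compound 1 `CC1(C)CN(c2cccnc2)C(=O)c2ccc(Cl)cc21` — a limit of the assay for compound 1: > 10000 nM
Compound 2 `Cc1ccc(C(=O)Nc2cccnc2)cc1` — a limit of the assay for compound 2: > 3000 nM
Compound 3 `N#Cc1ccc2c(c1)CN(c1cccnc1)C2=O` — compound 3 gives 15500 nM

Compound 2 stands only at a limit in this assay, so no number is known for it. Of the three values shown, one further one is also a limit, (the limit of > 10000 nM in this assay, at which 1 of the 3 values shown sits), while the limit of compound 2 is the limit of > 3000 nM in this assay, at which 1 of the 3 values shown sits; compound 3 alone gives a number, and that number is weak. Across these three compounds the series shows no strong inhibitor in this assay.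

Compound 4 `O=C(Nc1cccnc1)c1ccc(Cl)cc1` is not yet measured. It differs from compound 2 by chloro in place of methyl on an aromatic carbon. Among the measured compounds shown here, no measured pair shows the effect of this exchange, so there is no step to lean on. The expectation is that the step from compound 2 to compound 4 stays within the scatter of repeated measurements, with no change in direction that can be trusted, which is what a step that the limit leaves unreadable from compound 2 to compound 4 expresses. Compound 4 is accordingly expected to remain weak, estimated at 6000 nM with a range from 1500 nM to 25000 nM, and a fair chance that only a limit is reported again.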

Compound 4, half-maximal inhibitory concentration: > 3000 nM
Compound 4: no number, only a limit (the forecaster's own chance of this, stated with the estimate: 50%); the middle value does not contradict the limit.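

Compound 2 and compound 4 both stand only at a limit, so chloro in place of methyl on an aromatic carbon gives no readable step: the limit of > 3000 nM in this assay, at which 2 of the 4 values shown sit. The compounds shown leave open whether this exchange changes inhibition at all in this assay.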